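Compound 3 and the step from its methyl ester

A few compounds are considered here, and "the series" means these few. Any claim that something is new, unique, unknown or untested is made for them only; others in the source may bear on it.

- compound 1 `C=CC(=C)[C@@H](C[C@H]1C(=C)CC[C@H]2[C@](C)(CO)CCC[C@]12C)OO` gives 34400 nM 
- compound 2 `C=C/C(C)=C/[C@@H](OC(C)=O)[C@H]1C(=C)CC[C@@H]2[C@]1(C)CCC[C@@]2(C)C(=O)OC` gives 58300 nM 

Among the compounds with values here, both values come from a functional assay on PC-3 cells (Homo sapiens) for inhibition, read by colorimetric assay and MTT assay (on this read-out lower numbers stand for stronger inhibition of growth and higher numbers for weaker inhibition of growth), and are the only measurements available. Compound 2 stands within the scatter of compound 1, so the two cannot be ranked. Within the data shown here, they also differ in more than one place, and no measured pair shows the effect of a single change.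

Compound 3 `C=C/C(C)=C/[C@@H](OC(C)=O)[C@H]1C(=C)CC[C@@H]2[C@]1(C)CCC[C@@]2(C)C(=O)O` has not yet been measured. Among the measured compounds shown here, it departs from compound 2 by hydrogen in place of methyl on an oxygen next to a carbonyl group as its only change: hydrogen in place of methyl on an oxygen next to a carbonyl group, which turns methoxycarbonyl to carboxy. For the measured compounds named here, the data hold no direct precedent for this change, so the expectation starts from compound 2 at 58300 nM and assumes no clear shift in either direction. In this assay the estimated step of a 1.1-fold lower number from compound 2 to compound 3 (0.03 log units; within the scatter) is expected to stay within the scatter. For compound 3 the expected value is 55000 nM with an estimated range from 22000 nM to 130000 nM in this wide band.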

Compound 3, concentration for 50% growth inhibition: 57200 nM
Estimate against measurement, compound 3: 1.0-fold (0.02 log units) below; low and high end bracket the measured number.
By their numbers in this assay, from the lowest: compounds 1, 3 and 2 (each within the scatter of the next).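

The set now holds its first pair that differs in one place: in this assay, hydrogen in place of methyl on an oxygen next to a carbonyl group, which turns methoxycarbonyl to carboxy, gives a 1.0-fold lower number from compound 2 to compound 3 (0.01 log units; within the scatter), and this step lies within the scatter. At this position, on this shared core, the read-out therefore does not tell the methyl ester from the free carboxylic acid, something that compound 1 and compound 2, which differ in more than one place, could not show. Nothing at hand offers an explanation for this result.

As far as these compounds go, what stays open is whether other groups at this position, such as a primary amide or an ethyl ester, would read the same as methoxycarbonyl and carboxy, since this single step covers only methyl and hydrogen on that oxygen. Also open, from the compounds shown here alone, is whether a change elsewhere on the core, such as a free hydroxy group in place of the acetate on the side chain, would move the number beyond the scatter.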